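A few compounds are considered here, and "the series" means these few. Any claim that something is new, unique, unknown or untested is made for them only; others in the source may bear on it.

Among the compounds with values here, of the two compounds measured so far in a functional assay for inhibition, with a stated time of 5 min, tested at 1 mM (a lower number here means less inhibition, a higher number more inhibition at the concentration tested (going by the name of the read-out)), compound 1 `COc1ccc(/C(Cl)=C/C=C(\C#N)C(=O)c2c(C)[nH]c3ccccc23)cc1OC` has the higher reading, though that distinction carries little weight, since the only other measured compound lies within the scatter of it. In this assay compound 1 gives 66.4%. Its neighbour is compound 2 `COc1cc(/C(Cl)=C/C=C(\C#N)C(=O)c2c(C)[nH]c3ccccc23)cc(OC)c1OC`, which in this assay gives 58.2% for compound 2. The step of a number 8.2 percentage points lower from compound 1 to compound 2 (within the scatter) is within the scatter, so the two compounds cannot be told apart on this read-out.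

Compound 3 `COc1ccc(/C(Cl)=C/C=C(\C#N)C(=O)c2c(C)[nH]c3ccccc23)cc1` has not yet been measured. It differs from compound 1 by hydrogen in place of methoxy on an aromatic carbon. Within the data shown here, the one measured step that bears on this change is the one from compound 1 to compound 2, which put a methoxy in place of hydrogen on an aromatic carbon and moved the read-out by a number 8.2 percentage points lower from compound 1 to compound 2 (within the scatter), a shift within the scatter. The change to compound 3 runs the other way, taking a methoxy off. No step beyond the scatter is therefore expected in this assay. For compound 3 at most a slight rise is expected, as a number 1.6 percentage points higher from compound 1 to compound 3 (within the scatter) expresses. Compound 3 is expected to give about 68% in this assay, within a range from 52% to 82%.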

Compound 3, a percentage reported as inhibition, at one concentration (the size of the read-out at that concentration, not a potency): 63.1%
The estimate for compound 3 lay 4.9 percentage points above the measured number; the range from low to high includes it.
By their numbers in this assay, from the lowest: compounds 2, 3 and 1 (each within the scatter of the next).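

Taking the methoxy away from the aromatic carbon that is ortho to a methoxy group and meta to a large group gives, in this assay, a number 3.3 percentage points lower from compound 1 to compound 3 (within the scatter). The earlier compounds shown here showed only that adding a methoxy to the ring of compound 1 left the reading within the scatter, as a number 8.2 percentage points lower from compound 1 to compound 2 (within the scatter) records; compound 3 now shows the same for removing one, so on this read-out neither change to the methoxy pattern of compound 1 can be told apart from no change at all. No measurement offered here explains why the reading holds across this change.

The compounds shown carry only methoxy or hydrogen at this place, so it stays open whether an amine, a carboxylic acid or a longer chain such as butoxy on the same aromatic carbon would produce a step beyond the scatter in this assay. Going by these compounds, since this read-out is taken at one concentration, it also stays open whether compound 1 and compound 3 would still be indistinguishable at other concentrations, or with the remaining methoxy of compound 3 replaced as well.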